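This account rests on a few compounds, and the source may have more. Where it says the series, first, only, none or still open, it means among the compounds named here.

Working notes on the series. Four compounds share one core. Within the data shown here, compound 1, `O=C1O[C@H]([C@@H](O)Cn2ccc(NC(=O)c3ccccc3)nc2=O)C(OCc2ccccc2)=C1OCc1ccccc1`, is the only member that returns a number: in a functional assay on HeLa cells (Homo sapiens) for inhibition, read by MTT assay, with a stated time of 72 h (on this read-out lower numbers stand for stronger inhibition and higher numbers for weaker inhibition), compound 1 gives 35900 nM. Compound 2, `O=C1O/C(=C\Cn2c(=O)[nH]c(=O)[nH]c2=O)C(OCc2ccccc2)=C1OCc1ccccc1`, sits at the edge of the assay: in this assay compound 2 gives > 100000 nM, which is a limit of the assay and not a measured number. Compound 3, `NC1(CCn2ccc(=O)[nH]c2=O)OC(=O)C(OCc2ccccc2)=C1OCc1ccccc1`, sits there too: in this assay compound 3 gives > 100000 nM, again a limit and not a number. Where compound 3 stands is thus described by the limit of > 100000 nM in this assay, at which 2 of the 3 values shown sit; only compound 1 lies inside the measurable range. Compound 4, `NC1(CCn2cc(F)c(=O)[nH]c2=O)OC(=O)C(OCc2ccccc2)=C1OCc1ccccc1`, is the unmeasured analogue of compound 3 and differs from it in one place: fluoro in place of hydrogen on an aromatic carbon. No measured pair in the set isolates this change, so its size is unknown from the data, and nothing shown suggests the change would move a compound from the limit into the measurable range. For compound 4 the expectation is no step beyond the scatter in this assay, most probably another limit. The estimate for compound 4 is 100000 nM, with a range from 50000 nM to 300000 nM. The step this estimate implies is a number no higher from compound 3 to compound 4 (the limit leaves the size open), expected to stay within the scatter.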

Compound 4, half-maximal inhibitory concentration: > 100000 nM
Compound 4: a limit, no number (the forecaster's own chance of this, stated with the estimate: 70%); the middle value sits exactly at the limit.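

No step can be read from compound 3 to compound 4 in this assay, since both give a limit and not a number. The compounds shown leave open how large a change fluoro in place of hydrogen on an aromatic carbon brings, as no pair with this change lies inside the measurable range.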